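This account rests on a few compounds, and the source may have more. Where it says the series, first, only, none or still open, it means among the compounds named here.

Compound 3, whose structure is `C/N=C(\S)N(C)CCCCn1nc(-c2ccccc2)ccc1=O`, was tested in a functional assay on the whole organism with Rattus norvegicus as the target, at a dose of 100 mg/kg; a higher number here means more inhibition at the dose given (going by the name of the read-out), a lower number less inhibition; there compound 3 gives 17.5%, the lowest of the three numbers measured. Its closest neighbour is compound 2 `O=c1ccc(-c2ccccc2)nn1CCCCNC(=S)Nc1ccccc1`, which in this assay gives 38.4%, and the furthest is compound 1 `C/N=C(\S)NCCCCCn1nc(-c2ccccc2)ccc1=O`, which in this assay gives 68.9%. Among the compounds with values here, the one measured step at the same position, a number 51.4 percentage points lower from compound 1 to compound 3 (beyond the scatter), shows that the read-out in this assay reacts strongly to what is attached at this end of the chain.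

Compound 4 `C/N=C(\NC#N)NCCCCn1nc(-c2ccccc2)ccc1=O` has not yet been measured. It differs from compound 3 as follows: a group of 7 heavy atoms (3 carbon, 4 nitrogen; no ring) in place of a group of 6 heavy atoms (3 carbon, 2 nitrogen, 1 sulfur; no ring), on a saturated chain carbon, four bonds along the chain from an aromatic nitrogen. Within the data shown here, because the step of a number 51.4 percentage points lower from compound 1 to compound 3 (beyond the scatter) was large, a change of similar size at this place seems plausible for compound 4, but the direction cannot be read from a single step, and no measured pair shows the entering group itself. Compound 4 is therefore expected to move upward from compound 3, by a step of about a number 22.5 percentage points higher from compound 3 to compound 4 (beyond the scatter), to an estimated 40%, within a range from 15% to 70%.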

Compound 4, a percentage reported as inhibition, in the whole organism at one dose (the size of the read-out at that dose, not a potency): 79%
The estimate for compound 4 lay 39 percentage points below the measured number; the measured number lies above the stated range.
By their numbers in this assay, from the lowest: compound 3; then compound 2; then compound 1; then compound 4.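

At this place, on a saturated chain carbon, four bonds along the chain from an aromatic nitrogen, the read-out in this assay can also climb steeply: the group of 7 heavy atoms, which has no sulfur, replaces the sulfur-bearing group of 6 heavy atoms with a number 61.5 percentage points higher from compound 3 to compound 4 (beyond the scatter) as the result. With a number 40.6 percentage points higher from compound 2 to compound 4 (beyond the scatter) and a number 10.1 percentage points higher from compound 1 to compound 4 (beyond the scatter) as well, the sulfur-free group gives the highest number of the four, although that last step is only modest. Sulfur alone does not sort the numbers, however: compound 1 keeps it, gives 68.9% and still stands far above compound 3.

Nothing measured here says why the numbers move as they do. Also open, as far as these compounds go, is how an amine or a carboxylic acid at this place would read, and what a longer chain would do to the group of compound 4.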